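A few compounds are considered here, and "the series" means these few. Any claim that something is new, unique, unknown or untested is made for them only; others in the source may bear on it.

Among the measured compounds shown here, compound 1 `Cn1ccc2cc(-c3ccc4oc(NC5CCCCC5)nc4c3)ccc21` gives 911 nM in an assay on HEK293 cells for inhibition of Fatty-acid amide hydrolase 1 (Homo sapiens), read by fluorescence (on this read-out lower numbers stand for stronger inhibition and higher numbers for weaker inhibition), the highest of the three numbers measured so far. Compound 2 `c1cc2c(ccn2C2COC2)cc1-c1ccc2oc(NC3CCCCC3)nc2c1` gives 579 nM in this assay, and compound 3 `NC(=O)Cn1ccc2cc(-c3ccc4oc(NC5CCCCC5)nc4c3)ccc21` gives 214 nM. The step of a 1.6-fold lower number from compound 1 to compound 2 (0.20 log units; within the scatter) lies within the scatter, whereas a 4.3-fold lower number from compound 1 to compound 3 (0.63 log units; beyond the scatter) and a 2.7-fold lower number from compound 2 to compound 3 (0.43 log units; beyond the scatter) are modest but beyond it. All three of these steps alter the group on the aromatic nitrogen of the shared core. Compound 4 `CNc1nc2cc(-c3ccc4c(ccn4C)c3)ccc2o1` differs from compound 1 elsewhere: methyl in place of cyclohexyl on a nitrogen on an aromatic ring. For the measured compounds named here, no measured step touches this position, so none of them bears directly on the change; the measured steps only show that the other end of the molecule can shift the number by a modest amount. Here the ring of the cyclohexyl is removed and a single carbon remains, a change of a different kind from those measured. The account therefore expects compound 4 to give a higher number, an estimated step of a 3.3-fold higher number from compound 1 to compound 4 (0.52 log units; beyond the scatter), with wide uncertainty. The estimate for compound 4 is 3000 nM, within a range from 600 nM to 15000 nM.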

Compound 4, half-maximal inhibitory concentration: > 1000 nM
Compound 4 ended at the assay's limit; the forecaster's own chance of this, stated with the estimate: 15%; the middle value lies beyond the limit too.
By their numbers in this assay, from the lowest: compound 3; then compounds 2 and 1 (each within the scatter of the next). At a limit, above all of these: compound 4.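

In this assay compound 4 gives > 1000 nM, which is a limit of the assay and not a number, and the only value of its kind among those shown: the limit of > 1000 nM in this assay, at which 1 of the 4 values shown sits. Among the compounds shown here, this is the first reading at this position, and for the change from cyclohexylamino to methylamino it gives only a floor, an at least 1.0-fold higher number from compound 1 to compound 4 (0.04 log units; that floor lies within the scatter). The result therefore shows that methyl in place of cyclohexyl on this nitrogen does not bring the number below the limit, but it leaves the size of the rise unknown, and a step within the scatter is not excluded.

The compounds shown leave open how the number responds to an ethyl or propyl chain on this nitrogen, or to a cyclopropyl or cyclopentyl ring there. They also leave open whether carbamoylmethyl on the aromatic nitrogen would lower the number when methylamino replaces cyclohexylamino.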